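A Fluorine Step Carried From One Core to Another

The source may hold more compounds than are shown below. What is called first, only, known or untested is meant among the compounds shown, and "the series" means these compounds.

Four compounds are in view, three of them measured. Compound 1 `N/C(=N\NC(=S)N1CCCCCC1)c1ccccn1` and compound 2 `N/C(=N\NC(=S)N1CCOCC1)c1ccccn1` differ in the ring at one end; the difference between the two cores is not broken down here. Compound 3 `N/C(=N\NC(=S)N1CCOCC1)c1ccc(F)cn1` is compound 2 with fluoro in place of hydrogen on an aromatic carbon. Compound 4 `N/C(=N\NC(=S)N1CCCCCC1)c1ccc(F)cn1` is compound 1 with fluoro in place of hydrogen on an aromatic carbon. The place is described in the same words for both, so this is the same change made on two cores.

In a functional assay on MCF7 cells (Homo sapiens) for cytotoxicity, read by MTT assay, with a stated time of 72 h (a higher number here means a weaker inhibitor, a lower number a stronger inhibitor), compound 1 gives 2600 nM, compound 2 gives 4700 nM and compound 3 gives 22100 nM. The values of compound 1 and compound 2 lie within the usual scatter of each other. Going by the values given here, the only measured step, a 4.7-fold higher number from compound 2 to compound 3 (0.67 log units; beyond the scatter), is a modest weakening.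

Among the compounds with values here, the step from compound 1 to compound 4 is expected to be of a similar size, a 4.2-fold higher number from compound 1 to compound 4 (0.63 log units; beyond the scatter), because the sole measured example of this change is a 4.7-fold higher number from compound 2 to compound 3 (0.67 log units; beyond the scatter). Within the data shown here, with only one example, the expectation is loosely held. For compound 4 in this assay the estimated value is 11000 nM, likely between 5000 nM and 30000 nM.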

Compound 4, half-maximal inhibitory concentration: 21100 nM
Beside the measured number, compound 4's estimate is 1.9-fold (0.28 log units) below it; measured number inside the range.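

Fluoro in place of hydrogen on an aromatic carbon again weakens the result in this assay, with an 8.1-fold higher number from compound 1 to compound 4 (0.91 log units; beyond the scatter). Set side by side, the two steps go the same way and do not differ in size beyond what repeated measurements would be expected to give: the same change on two cores in this assay, a 4.7-fold higher number (0.67 log units; beyond the scatter) from compound 2 to compound 3 and an 8.1-fold higher number (0.91 log units; beyond the scatter) from compound 1 to compound 4, 1.7-fold (0.24 log units) apart, within the scatter of two such steps. This shows that the change carried over between these two cores, but two cores are a small sample, so it does not show that the same would hold on any other core, nor does it explain why the number rises.

Going by these compounds, at this place on the aromatic ring, only hydrogen and fluoro appear, so it remains open whether chloro, methyl or methoxy would also give a higher number than hydrogen. The other end of the molecule appears only as two rings, which leaves open how an open-chain group such as dimethylamino would respond to the same fluoro change.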